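This account rests on a few compounds, and the source may have more. Where it says the series, first, only, none or still open, it means among the compounds named here.

Among the measured compounds shown here, compound 2, `Cc1cc(O)c(C2=NN(c3ccc(S(N)(=O)=O)cc3)C(/C=C/c3ccccc3)C2)cc1Cl`, is one of two compounds measured in a functional assay on RPMI-8226 cells (Homo sapiens) for antiproliferative activity, with a stated time of 48 h; a higher number here means a weaker inhibitor of growth, a lower number a stronger inhibitor of growth. Compound 2 gives 20600 nM, the highest of the two numbers, while compound 1, `Cc1cc(O)c(C2=NN(c3ccc(S(N)(=O)=O)cc3)C(c3ccccc3Cl)C2)cc1Cl`, gives 8350 nM. For the measured compounds named here, the single step between them, a 2.5-fold higher number from compound 1 to compound 2 (0.39 log units; beyond the scatter), is the only step available and is the one that bears on what follows.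

Compound 3, `COc1ccc(C2CC(c3cc(Cl)c(C)cc3O)=NN2c2ccc(S(N)(=O)=O)cc2)cc1OC`, has not yet been measured in this assay. It differs from compound 2 in one place: 3,4-dimethoxyphenyl in place of 2-phenylethenyl on a saturated ring carbon. The change returns an aromatic ring to the saturated ring carbon, where compound 1 also carries an aromatic ring rather than the 2-phenylethenyl group of compound 2. Going by the values given here, the step of a 2.5-fold higher number from compound 1 to compound 2 (0.39 log units; beyond the scatter) went the other way, from an aromatic ring to 2-phenylethenyl, and raised the number modestly; a step back to an aromatic ring is therefore expected to lower the number by a comparable amount, though the two methoxy groups of compound 3 have no counterpart among the measured compounds, so the range must stay wide. Compound 3 is therefore estimated at 10000 nM in this assay, within a range of 4000 nM to 25000 nM, meaning an expected step of a 2.1-fold lower number from compound 2 to compound 3 (0.31 log units; beyond the scatter).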

Compound 3, concentration for total growth inhibition: 100000 nM
Compound 3: the middle estimate sits 10-fold (1.00 log units) below what was measured, outside the stated range (above it).
By their numbers in this assay, from the lowest: compound 1; then compound 2; then compound 3.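

In this assay, the aromatic ring alone does not keep the number low at this saturated ring carbon: compound 1 and compound 3 both carry one there, yet the change from 2-chlorophenyl to 3,4-dimethoxyphenyl gives a 12-fold higher number from compound 1 to compound 3 (1.08 log units; beyond the scatter), a large step. The replacement of 2-phenylethenyl by 3,4-dimethoxyphenyl gives a 4.9-fold higher number from compound 2 to compound 3 (0.69 log units; beyond the scatter), so among these three groups 3,4-dimethoxyphenyl goes with the weakest inhibition of growth, and the identity of the ring and what it carries matter more here than the earlier pair could show. Nothing available accounts for this rise in the number.

The compounds shown leave open whether the rise goes with both methoxy groups or with only one of them, and a plain phenyl, a 3-methoxyphenyl or a 4-methoxyphenyl group on this carbon would be needed to separate those readings. They also leave open whether a 3,4-dihydroxyphenyl group or a phenyl ring bearing a dimethylamino group would follow 3,4-dimethoxyphenyl or return towards 2-chlorophenyl.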